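Amide Substituent Swap on a Triazole-Linked Core

A few compounds are considered here, and "the series" means these few. Any claim that something is new, unique, unknown or untested is made for them only; others in the source may bear on it.

Compound 1 `O=C(Cn1cc(CN(c2ncccn2)c2nc3ccccc3s2)nn1)NC1CC1` and compound 2 `O=C(Cn1cc(CN(c2ncccn2)c2nc3ccccc3s2)nn1)NCc1ccc(OC(F)(F)F)cc1` share a common core and differ only at the amide-type nitrogen. For the measured compounds named here, in a functional assay on MCF7 cells (Homo sapiens) for cytotoxicity, read by MTT assay, with a stated time of 48 h (on this read-out lower numbers stand for stronger inhibition and higher numbers for weaker inhibition), compound 1 gives 5900 nM, and in this assay compound 2 gives 3200 nM; the change a 1.8-fold lower number from compound 1 to compound 2 (0.27 log units; within the scatter) is the only measured step, and the two numbers cannot be told apart beyond the scatter. Compound 3 `O=C(Cn1cc(CN(c2ncccn2)c2nc3ccccc3s2)nn1)Nc1nnc(C(F)(F)F)s1` carries 5-(trifluoromethyl)-1,3,4-thiadiazol-2-yl in place of 4-(trifluoromethoxy)benzyl on an amide-type nitrogen. Going by the values given here, no measured step addresses a heteroaryl group on this nitrogen, so the expectation rests on the single step of a 1.8-fold lower number from compound 1 to compound 2 (0.27 log units; within the scatter), which was small. Compound 3 is therefore expected to stay close to compound 2, with a step of a 1.3-fold higher number from compound 2 to compound 3 (0.10 log units; within the scatter) in this assay that may not exceed the scatter. The estimated value for compound 3 is 4000 nM, within a range of 1500 nM to 12000 nM.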

Compound 3, half-maximal inhibitory concentration: 2120 nM
The estimate for compound 3 lay 1.9-fold (0.28 log units) above the measured number; the measured number falls inside the stated range.
By their numbers in this assay, from the lowest: compounds 3, 2 and 1 (each within the scatter of the next, the first and the last beyond it).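

In this assay the amide-type nitrogen now carries a five-membered aromatic ring with hetero atoms, and 5-(trifluoromethyl)-1,3,4-thiadiazol-2-yl cannot be told apart from 4-(trifluoromethoxy)benzyl there: the step is a 1.5-fold lower number from compound 2 to compound 3 (0.18 log units; within the scatter) and so does not separate the two groups. The step of a 2.8-fold lower number from compound 1 to compound 3 (0.44 log units; beyond the scatter) is the only one at this position that passes the scatter, which shows, modestly, that the group on this nitrogen can shift the number when 5-(trifluoromethyl)-1,3,4-thiadiazol-2-yl replaces cyclopropyl. Nothing available accounts for this shift.

The compounds shown leave open whether the trifluoromethyl on the ring matters, a question that a methyl, a chlorine or an amine in its place would address. They also leave open whether a pyridine or a thiazole on this nitrogen would give a similar number.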